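The compounds below may be only part of what the source reports. "The series", "measured", "known", "first", "only" and "open" are said of these compounds alone.

Compound 3 `SC1=NC(n2nc(-c3ccccc3)nc2-c2ccccc2)=CC(c2ccc(Br)cc2)N1` in a functional assay on the whole organism with Mus musculus as the target, in the maximal electroshock model, with a stated time of 4 h (a higher number here means that more compound is needed for the effect, a lower number that less compound is needed), gives 300 mg/kg; it stands level with compound 1 `SC1=NC(n2nc(-c3ccccc3)nc2-c2ccccc2)=CC(c2ccccc2Cl)N1`, which in this assay gives 300 mg/kg, and with compound 2 `SC1=NC(n2nc(-c3ccccc3)nc2-c2ccccc2)=CC(c2ccc(-c3ccccc3)cc2)N1`, which in this assay gives 300 mg/kg. Across the three, the group on the saturated ring carbon has been varied without effect: no change at the digits printed from compound 1 to compound 2 (within the scatter), no change at the digits printed from compound 1 to compound 3 (within the scatter) and no change at the digits printed from compound 2 to compound 3 (within the scatter) are all within the scatter.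

Compound 4 `Oc1ccc(C2C=C(n3nc(-c4ccccc4)nc3-c3ccccc3)N=C(S)N2)cc1` differs from compound 3 in one place: hydroxy in place of bromo on an aromatic carbon. The change sits on the aromatic carbon para to a large group, the same site where bromo replaced phenyl from compound 2 to compound 3 with no change at the digits printed from compound 2 to compound 3 (within the scatter). That step is the only one bearing directly on this exchange, and it was flat; the other two steps, also flat, moved the whole aryl group at the saturated ring carbon. Within the data shown here, no step has so far moved the read-out beyond the scatter, so the expected step is no change at the digits printed from compound 3 to compound 4 (within the scatter), that is none beyond the scatter. Compound 4 is therefore expected to give about 300 mg/kg in this assay, with a range from 100 mg/kg to 600 mg/kg.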

Compound 4, minimum effective dose: 300 mg/kg
Estimate against measurement, compound 4: no gap at the digits printed, and the stated range covers the measured number.
By their numbers in this assay, from the lowest: compounds 1, 2, 3 and 4 (each within the scatter of the next).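

In this assay, hydroxy in place of bromo on the aromatic carbon gives no change at the digits printed from compound 3 to compound 4 (within the scatter) and so leaves the read-out unmoved, although hydroxy counts 1 hydrogen-bond donor and 1 hydrogen-bond acceptor where bromo counts 0 of each. Hydroxy in place of phenyl at this carbon reads the same (no change at the digits printed from compound 2 to compound 4 (within the scatter)), as does 4-hydroxyphenyl in place of 2-chlorophenyl on the saturated ring carbon (no change at the digits printed from compound 1 to compound 4 (within the scatter)). No measured evidence bears on this flat result.

With all four compounds level, the series does not yet show whether any group at this site can move the read-out beyond the scatter. On these data alone, whether an amine or a carboxylic acid on this aromatic carbon would do so, or a change in the shared core instead, stays open.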